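This account rests on a few compounds, and the source may have more. Where it says the series, first, only, none or still open, it means among the compounds named here.

Compound 1 `COC(=O)CC/C=C\CC[C@H]1C(=O)C[C@@H](O)[C@@H]1/C=C/C[C@@](C)(O)/C=C/C1=CCCC1` is tested in a functional assay on the whole organism with Rattus norvegicus as the target; a lower number here means that less compound is needed, a higher number that more compound is needed for the effect. In this assay compound 1 gives only a limit, > 3.16 mg/kg, and so stands at the limit of > 3.16 mg/kg in this assay, at which 1 of the 2 values shown sits, rather than at a number. Compound 2 `COC(=O)CC/C=C\CC[C@H]1C(=O)C[C@@H](O)[C@@H]1/C=C/C[C@@](C)(O)/C=C/C1CCCC1` gives 1.95 mg/kg in this assay, and the step of an at least 1.6-fold lower number from compound 1 to compound 2 (0.20 log units; that floor lies within the scatter) shows that cyclopentyl in place of cyclopent-1-en-1-yl lowers the number. Compound 3 `COC(=O)CC/C=C\CC[C@H]1C(=O)C[C@@H](O)[C@@H]1/C=C/C[C@@](C)(O)/C=C/C1(C)CC1` carries the change (1-methylcyclopropyl in place of cyclopent-1-en-1-yl on a double-bonded chain carbon bound to a double-bonded chain carbon). For the measured compounds named here, only that one measured step bears on it, and its floor lies within the scatter, so for compound 3 a step of similar size is expected, an at least 1.2-fold lower number from compound 1 to compound 3 (0.10 log units; that floor lies within the scatter). Compound 3 is therefore expected to give about 2.5 mg/kg in this assay, most likely between 1 mg/kg and 6.3 mg/kg.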

Compound 3, dose for half-maximal effect: 1.34 mg/kg
Beside the measured number, compound 3's estimate is 1.9-fold (0.27 log units) above it, and the stated range covers the measured number.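

For the compounds shown here, replacing cyclopent-1-en-1-yl with 1-methylcyclopropyl on this double-bonded chain carbon gives an at least 2.3-fold lower number from compound 1 to compound 3 (0.37 log units; beyond the scatter), the first change here to clear the scatter. In this assay, 1-methylcyclopropyl and cyclopentyl cannot be told apart, with a 1.5-fold lower number from compound 2 to compound 3 (0.16 log units; within the scatter). The true size of the first step stays unknown, and it can only be read as a floor, because compound 1 gives only a limit: the limit of > 3.16 mg/kg in this assay, at which 1 of the 3 values shown sits.

The compounds shown leave open whether a ring is needed on this carbon at all. An open butyl chain or a phenyl group there would help to settle that.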